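The source may report more compounds than this note shows. Statements on the series, on what has been measured and on what is new or still open speak of the compounds shown alone.

Compound 1 `COc1cc(C)cc(-c2c(-c3ccnc(-c4ccc(N(C)C)cc4)c3)cnn2CC#N)c1`: > 100000 nM in a functional assay on T47D cells (Homo sapiens) for inhibition, read by sulforhodamine B assay, with a stated time of 48 h (on this read-out lower numbers stand for stronger inhibition of growth and higher numbers for weaker inhibition of growth), a limit rather than a number.
Compound 2 `COc1cc(C)cc(-c2nn(CC#N)cc2-c2ccnc(-c3ccc(N(C)C)cc3)c2)c1`: 17300 nM.
Compound 3 `COc1cc(C)cc(-c2nn(CC#N)cc2-c2ccc(-c3cccc(C(C)=O)c3)nc2)c1`: 8230 nM.

Among the two compounds that give an actual number in this assay, compound 2 holds the higher one, meaning the weaker inhibition of growth; compound 3 sits lower, and that gap lies beyond the usual scatter of repeat measurements. Compound 1 reports only a limit, (the limit of > 100000 nM in this assay, at which 1 of the 3 values shown sits).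

Compound 4 `Cc1cc(O)cc(-c2nn(CC#N)cc2-c2ccnc(-c3ccc(N(C)C)cc3)c2)c1` differs from compound 2 in one place: hydrogen in place of methyl on an oxygen on an aromatic ring. Within the data shown here, no measured pair shows this change, so its effect is unknown. The expected step of a 1.2-fold lower number from compound 2 to compound 4 (0.06 log units; within the scatter) is small and without a clear direction, within the usual scatter. Compound 4 is therefore estimated at 15000 nM, between 4000 nM and 60000 nM.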

Compound 4, concentration for total growth inhibition: 12400 nM
For compound 4 the middle estimate is 1.2-fold (0.08 log units) above the measured one; the range from low to high includes it.
By their numbers in this assay, from the lowest: compounds 3, 4 and 2 (each within the scatter of the next, the first and the last beyond it). At a limit, above all of these: compound 1.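

Going from methoxy to hydroxy on the aromatic ring gives a 1.4-fold lower number from compound 2 to compound 4 (0.14 log units; within the scatter) in this assay, so the methyl on this oxygen can be lost without a difference that this read-out can separate from scatter. This is the first pair shown that differs in one place, and it gives this position its first reading. Nothing measured here accounts for the size of this step.

From the compounds shown here alone, what a longer chain on this oxygen, such as ethoxy, or an amine in place of the hydroxy would do remains open. Going by these compounds, whether the same change behaves alike on the other compounds also stays open, as this is a single pair.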